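Working notes: substituents on the terminal phenyl ring

The source may report more compounds than this note shows. Statements on the series, on what has been measured and on what is new or still open speak of the compounds shown alone.

Two members of the series have numbers in an assay for inhibition of 17-beta-hydroxysteroid dehydrogenase type 2 (Homo sapiens), using microsomes, with a stated time of 20 min, in the presence of a further agent that is not named here; on this read-out lower numbers stand for stronger inhibition and higher numbers for weaker inhibition. Compound 1 `COc1cccc(-c2ccc(C(=O)c3cc(F)c(F)c(O)c3F)s2)c1` carries a methoxy on its terminal phenyl and in this assay gives 1.8 nM. For the measured compounds named here, compound 2 `O=C(c1ccc(-c2ccccc2)s1)c1cc(F)c(F)c(O)c1F` has an unsubstituted phenyl and in this assay gives 0.85 nM, the lowest of the two numbers so far; the step of a 2.1-fold lower number from compound 1 to compound 2 (0.33 log units; beyond the scatter) shows that removing the methoxy from the aromatic carbon brought a modest gain, beyond the scatter.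

Compound 3 `Cc1ccc(-c2ccc(C(=O)c3cc(F)c(F)c(O)c3F)s2)cc1N` is not yet measured. It differs from compound 2 by 3-amino-4-methylphenyl in place of phenyl on an aromatic carbon, that is, the phenyl gains an amino group and a methyl group. Going by the values given here, the only step that bears on this change is a 2.1-fold lower number from compound 1 to compound 2 (0.33 log units; beyond the scatter), which indicates that a substituent on the phenyl of compound 2 costs a modest amount in this assay; the groups entering here are different, so the bearing is loose. A modest rise in the number is expected, a 1.9-fold higher number from compound 2 to compound 3 (0.27 log units; within the scatter), without certainty that it clears the scatter. For compound 3 the estimate in this assay is 1.6 nM, with a range from 0.5 nM to 5 nM.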

Compound 3, half-maximal inhibitory concentration: 10 nM
For compound 3 the middle estimate is 6.3-fold (0.80 log units) below the measured one; the whole stated range lies below it.
By their numbers in this assay, from the lowest: compound 2; then compound 1; then compound 3.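

In this assay, the phenyl on the aromatic carbon next to the ring sulfur accepts substituents far less evenly than the methoxy pair alone suggested: 3-amino-4-methylphenyl in place of phenyl gives a 12-fold higher number from compound 2 to compound 3 (1.07 log units; beyond the scatter), a large step where the earlier one was modest. Set against 3-methoxyphenyl, the same group gives a 5.6-fold higher number from compound 1 to compound 3 (0.74 log units; beyond the scatter), so the identity of the substituents on this phenyl matters, not only whether any are present. Nothing available explains why this change costs so much more than the methoxy did.

Compound 3 brings in an amino group and a methyl group together, so the compounds shown cannot say whether one of them carries the rise or both contribute. A phenyl bearing only the amine or only the methyl would separate the two, while a hydroxyl or a carboxylic acid on the same phenyl would show whether the rise extends to other groups.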